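The source may report more compounds than this note shows. Statements on the series, on what has been measured and on what is new or still open speak of the compounds shown alone.

Among the measured compounds shown here, compound 2 `COc1cc2c(Oc3ccc(NC(=O)c4nnn(-c5ccc(C)cc5)c4C(F)(F)F)cc3F)ccnc2cc1OCCCN1CCCC1` stands highest of the two numbers so far in a functional assay on A549 cells (Homo sapiens) for cytotoxicity, read by MTT assay, with a stated time of 72 h (a lower number here means a stronger inhibitor, a higher number a weaker inhibitor), where compound 2 gives 370 nM while compound 1 `COc1cc2c(Oc3ccc(NC(=O)c4nnn(-c5ccccc5C(F)(F)F)c4C)cc3F)ccnc2cc1OCCCN1CCCC1` gives 160 nM, a gap beyond the usual scatter. Compound 3 `COc1cc2c(Oc3ccc(NC(=O)c4nnn(-c5ccccc5C(F)(F)F)c4C(F)(F)F)cc3F)ccnc2cc1OCCCN1CCCC1` carries 2-(trifluoromethyl)phenyl in place of 4-methylphenyl on an aromatic nitrogen, the same aryl group that compound 1 bears. For the measured compounds named here, no measured pair isolates this change, so one expects only a modest step toward the lower number, about a 1.7-fold lower number from compound 2 to compound 3 (0.23 log units; within the scatter), because compound 1 with that same aryl group reads 160 nM. The expected value for compound 3 in this assay is 220 nM, within 90 nM to 550 nM.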

Compound 3, half-maximal inhibitory concentration: 200 nM
Estimate against measurement, compound 3: 1.1-fold (0.04 log units) above, and the stated range covers the measured number.
By their numbers in this assay, from the lowest: compounds 1, 3 and 2 (each within the scatter of the next, the first and the last beyond it).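

In this assay, 2-(trifluoromethyl)phenyl in place of 4-methylphenyl on the aromatic nitrogen gives a 1.9-fold lower number from compound 2 to compound 3 (0.27 log units; within the scatter), and trifluoromethyl in place of methyl on the aromatic carbon gives a 1.3-fold higher number from compound 1 to compound 3 (0.10 log units; within the scatter). Among the compounds shown here, these are the first single-place steps, and neither change moves the number beyond the scatter. No measurement here speaks to why these steps are so small. The compounds shown leave open how an amine or a carboxylic acid on the aryl group would read, and how a longer chain would read in place of the trifluoromethyl group on the aromatic carbon.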